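This account rests on a few compounds, and the source may have more. Where it says the series, first, only, none or still open, it means among the compounds named here.

Measured compounds:
- compound 1, `NC(=O)[C@@H]1CCN1Cc1ccc(OCc2cccc(F)c2)cc1`: 21 nM
- compound 2, `C[C@H](NCc1ccc(OCc2cccc(F)c2)cc1C1CC1)C(N)=O`: 1660 nM
- compound 3, `NC(=O)[C@@H]1CCN1Cc1ccc(OCc2cccc(F)c2)cc1Cl`: 35 nM

These three compounds were tested in an assay on Sf9 cells for inhibition of Amine oxidase [flavin-containing] B (Homo sapiens), with stated times of 15 min and 60 min; a lower number here means a stronger inhibitor, a higher number a weaker inhibitor. Compound 3 stands second highest of the three numbers. Its nearest neighbour is compound 1, and the step of a 1.7-fold higher number from compound 1 to compound 3 (0.22 log units; within the scatter) lies within the usual scatter, so the two cannot be told apart on these numbers. Compound 2, with its open-chain amide and cyclopropyl group, gives the highest number of the set and sits far from compound 3.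

Compound 4, `NC(=O)[C@@H]1CCN1Cc1ccc(OCc2cccc(F)c2)cc1F`, has not yet been measured. It differs from compound 3 in one place: fluoro in place of chloro on an aromatic carbon. Among the measured compounds shown here, the only measured step that bears on this position is the one from compound 1 to compound 3, where chloro replaced hydrogen and the number moved by an amount within the scatter. A fluoro, like chloro, is a single halogen atom at this aromatic carbon, so no step beyond the scatter is expected in this assay in either direction. Compound 4 is therefore estimated at 26 nM, with a range of 10 nM to 70 nM, which means an expected step of a 1.3-fold lower number from compound 3 to compound 4 (0.13 log units; within the scatter).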

Compound 4, half-maximal inhibitory concentration: 26 nM
Compound 4: middle estimate and measured number agree at the digits printed, within the range that was stated.
By their numbers in this assay, from the lowest: compounds 1, 4 and 3 (each within the scatter of the next); then compound 2.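

In this assay the exchange of one halogen for the other at this aromatic carbon gives a 1.3-fold lower number from compound 3 to compound 4 (0.13 log units; within the scatter), so fluoro and chloro cannot be told apart here. Fluoro against plain hydrogen gives a 1.2-fold higher number from compound 1 to compound 4 (0.09 log units; within the scatter), and together with the earlier chloro step (a 1.7-fold higher number from compound 1 to compound 3 (0.22 log units; within the scatter)) this shows that hydrogen, fluoro and chloro ortho to the (2-carbamoylazetidin-1-yl)methyl group all give numbers within the scatter of one another. No measurement on hand offers an explanation for this result.

From the compounds shown here alone, what a methoxy group, a nitrile or an amine would do at this same carbon remains open. Compound 2 carries a cyclopropyl group on the ring but also differs in its amide part, so the effect of cyclopropyl alone cannot be read from it.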